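Chain extension on the aromatic ether oxygen, compounds 2 and 3

A few compounds are considered here, and "the series" means these few. Any claim that something is new, unique, unknown or untested is made for them only; others in the source may bear on it.

Measured so far:
compound 1, `CCCCCOc1ccc(-c2c(C)[nH]c(=O)n2C)cc1`, 4500 nM
compound 2, `CCCCCOc1ccc(-c2c(C)[nH]c(=O)n2C2CCCCC2)cc1`, 9100 nM

In a functional assay on brain (Rattus norvegicus, strain Wistar) for inhibition (a higher number here means a weaker inhibitor, a lower number a stronger inhibitor), compound 1 gives 4500 nM and compound 2 gives 9100 nM. For the measured compounds named here, compound 2 stands at the higher of the two numbers; the only measured step, cyclohexyl in place of methyl on an aromatic nitrogen, runs a 2.0-fold higher number from compound 1 to compound 2 (0.31 log units; beyond the scatter).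

Compound 3, `CCCCCCCCOc1ccc(-c2c(C)[nH]c(=O)n2C2CCCCC2)cc1`, keeps the cyclohexyl on the aromatic nitrogen and differs from compound 2 only in the saturated chain on the oxygen of the aromatic ring: propyl in place of hydrogen on a saturated chain carbon, five bonds along the chain from an oxygen on an aromatic ring.

Going by the values given here, no measured step touches that chain. Among the compounds with values here, the single step in this assay concerns the substituent on the aromatic nitrogen, not the chain, so nothing measured bears on the change from compound 2 to compound 3. With no reference for extending this chain, no step beyond the scatter is expected in either direction, and the estimate for compound 3 is set close to compound 2 with a wide range.

For compound 3 the expected value in this assay is 9000 nM, between 3000 nM and 30000 nM. The expected step is a 1.0-fold lower number from compound 2 to compound 3 (0.00 log units; within the scatter).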

Compound 3, half-maximal inhibitory concentration: 8500 nM
Compound 3: the middle estimate sits 1.1-fold (0.02 log units) above what was measured; measured number inside the range.
By their numbers in this assay, from the lowest: compounds 1, 3 and 2 (each within the scatter of the next, the first and the last beyond it).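

In this assay, propyl in place of hydrogen on a saturated chain carbon, five bonds along the chain from an oxygen on an aromatic ring, gives a 1.1-fold lower number from compound 2 to compound 3 (0.03 log units; within the scatter), so with cyclohexyl on the aromatic nitrogen this chain position takes the three added carbons with no readable shift in the number. For the compounds shown here, this is the first reading on the chain: the earlier step, a 2.0-fold higher number from compound 1 to compound 2 (0.31 log units; beyond the scatter), concerned only the substituent on the aromatic nitrogen and lies beyond the scatter, whereas the chain step lies within it. No independent evidence is available to account for this result.

The compounds shown leave open whether the chain behaves the same way with methyl on the aromatic nitrogen, as the only chain pair here carries cyclohexyl. Also open, from the compounds shown here alone, is whether a longer chain, or an amine or a carboxylic acid on this chain, would move the number beyond the scatter in either direction.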